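A few compounds are considered here, and "the series" means these few. Any claim that something is new, unique, unknown or untested is made for them only; others in the source may bear on it.

Compound 3 `O=C(CN(c1nc(Cl)nc2[nH]cnc12)C1CC1)N[C@@H](CC(=O)OCc1ccccc1)C(=O)OCc1ccccc1` gives 22.4% in a functional assay on the whole organism (Tail, strain ICR) with Mus musculus as the target, in the tail flick test, with a stated time of 60 min, at a dose of 25 umol/kg by the oral route (a higher number here means a stronger effect of the compound at the dose given, a lower number a weaker effect), the lowest of the three numbers measured: compound 2 `C[C@@H](O)[C@H](NC(=O)CN(c1nc(Cl)nc2[nH]cnc12)C1CC1)C(=O)OCc1ccccc1` gives 29.7% and compound 1 `O=C(CN(c1nc(Cl)nc2[nH]cnc12)C1CC1)NCC(=O)OCc1ccccc1` gives 41.9%. Compound 4 `CC[C@H](C)[C@H](NC(=O)CN(c1nc(Cl)nc2[nH]cnc12)C1CC1)C(=O)OCc1ccccc1` differs from compound 3 by sec-butyl in place of (benzyloxycarbonyl)methyl on a saturated chain carbon bound to an amide-type nitrogen and a carbonyl carbon. Going by the values given here, two steps touch this carbon: a number 19.5 percentage points lower from compound 1 to compound 3 (beyond the scatter), and a number 7.3 percentage points lower from compound 2 to compound 3 (within the scatter). Compound 1, with hydrogen there, stands highest, and a number 12.2 percentage points lower from compound 1 to compound 2 (beyond the scatter) shows that 1-hydroxyethyl already cost something. Sec-butyl, with no ring and no hydrogen-bond acceptors, is nearer to hydrogen than either group, so a modest rise is expected, the estimated step being a number 10.6 percentage points higher from compound 3 to compound 4 (beyond the scatter). Compound 4 is therefore expected to give 33%, in the range 18% to 48%.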

Compound 4, a percentage reported as activity, at one dose (the size of the read-out at that dose, not a potency): 40.6%
For compound 4 the middle estimate is 7.6 percentage points below the measured one, within the range that was stated.
By their numbers in this assay, from the lowest: compounds 3 and 2 (each within the scatter of the next); then compounds 4 and 1 (each within the scatter of the next).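

In this assay, sec-butyl on the saturated chain carbon bound to an amide-type nitrogen and a carbonyl carbon does not bring the loss seen with the other two groups: the read-out shows a number 1.3 percentage points lower from compound 1 to compound 4 (within the scatter), alongside a number 18.2 percentage points higher from compound 3 to compound 4 (beyond the scatter) and a number 10.9 percentage points higher from compound 2 to compound 4 (beyond the scatter). A group on this carbon therefore does not lower the read-out as such, since compounds 2 and 3 fall short of compound 1 while compound 4 does not. Nothing available explains this difference between the groups. On these data alone, it remains open whether a methyl group, an unbranched butyl chain, a free carboxylic acid or an amine on this carbon would stand with compound 4 or with compounds 2 and 3.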